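The source may hold more compounds than are shown below. What is called first, only, known or untested is meant among the compounds shown, and "the series" means these compounds.

Measured compounds in an assay for inhibition of Nitric oxide synthase, inducible (Homo sapiens), read by scintillation counting, with a stated time of 30 min, tested at 1 mM; a lower number here means less inhibition, a higher number more inhibition at the concentration tested (going by the name of the read-out):
compound 1, `CCCC(=O)NCCC(=O)c1cc(OC)ccc1N`: 7.35%
compound 2, `CCCCC(=O)NCCC(=O)c1cc(OC)ccc1N`: 14.1%
compound 3, `COc1ccc(N)c(C(=O)CCNC(=O)C2CCC2)c1`: 0.01%

Compound 3 carries the smallest of the three numbers, though its separation from compound 1 is narrow: a number 7.3 percentage points lower from compound 1 to compound 3 (within the scatter). Against compound 2 the gap is wider: a number 14.1 percentage points lower from compound 2 to compound 3 (beyond the scatter). The remaining pair, a number 6.8 percentage points higher from compound 1 to compound 2 (within the scatter), shows that lengthening the chain by one carbon moved the read-out little.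

Compound 4, `COc1ccc(N)c(C(=O)CCNC(=O)C2CCCCC2)c1`, is the next step out from compound 3: cyclohexyl in place of cyclobutyl on a carbonyl carbon. Among the measured compounds shown here, the steps that bear on it are the two in which a cyclobutyl replaced a chain on the carbonyl carbon, both of which lowered the number, and the chain-lengthening step, which stayed within the scatter. None of them tells how enlarging the ring itself would read, and with compound 3 already close to the floor of the read-out there is little room to fall further. The expectation for compound 4 in this assay is therefore no step beyond the scatter, a number 6 percentage points higher from compound 3 to compound 4 (within the scatter), with an estimated value of 6% in the range 0% to 18%.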

Compound 4, a percentage reported as inhibition, at one concentration (the size of the read-out at that concentration, not a potency): 9.24%
Compound 4: middle estimate off by 3.2 percentage points, on the low side; low and high end bracket the measured number.
By their numbers in this assay, from the lowest: compounds 3, 1, 4 and 2 (each within the scatter of the next, the first and the last beyond it).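

In this assay, the larger ring on the carbonyl carbon leaves the read-out within the scatter of the smaller one (a number 9.2 percentage points higher from compound 3 to compound 4 (within the scatter)), so cyclobutyl and cyclohexyl cannot be told apart at this position. Cyclohexyl also cannot be told apart from either open chain (a number 4.9 percentage points lower from compound 2 to compound 4 (within the scatter); a number 1.9 percentage points higher from compound 1 to compound 4 (within the scatter)), which shows that replacing butyl with a ring does not in itself give a step beyond the scatter: cyclohexyl in compound 4 does not, while cyclobutyl in compound 3 does. Nothing available explains these readings.

Open, from the compounds shown here alone, is how a cyclopentyl, a phenyl or a longer chain would read on this carbonyl carbon. Also open, going by these compounds, is whether a carboxylic acid or an amine at the end of the chain would give a step beyond the scatter.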